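Adding a ring acetoxy to compound 3

A few compounds are considered here, and "the series" means these few. Any claim that something is new, unique, unknown or untested is made for them only; others in the source may bear on it.

- Compound 1 `CCCC[C@H](OC(C)=O)[C@@H](O)[C@H](O)[C@@H]1OC(=O)C=C[C@@H]1OC(C)=O` gives > 20 ug/mL as a limit
- Compound 2 `CCCC[C@@H](/C=C\[C@@H]1OC(=O)C[C@@H](OC)[C@@H]1O)OC(C)=O` gives > 20 ug/mL as a limit
- Compound 3 `CCCC[C@H](OC(C)=O)[C@@H](OC(C)=O)[C@H](OC(C)=O)[C@H]1CC=CC(=O)O1` gives 8.6 ug/mL as a number

These three compounds were tested in a functional assay on KB-V1 cells (Homo sapiens) for cytotoxicity, read by sulforhodamine B assay, with a stated time of 72 h (a higher number here means that more compound is needed for the effect, a lower number that less compound is needed), and only compound 3 gave a true number (read-out 8.6 ug/mL). Compound 1 and compound 2 reached no number, and they stand at the limit of > 20 ug/mL in this assay, at which 2 of the 3 values shown sit, without showing how far the real values lie beyond it.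

The next compound to be tested is compound 4 `CCCC[C@H](OC(C)=O)[C@@H](OC(C)=O)[C@H](OC(C)=O)[C@@H]1OC(=O)C=C[C@@H]1OC(C)=O`. It keeps the chain of compound 3 and changes the ring, with acetoxy in place of hydrogen on a saturated ring carbon, next to the ring atom that bears a large group (acetoxy in place of hydrogen on a saturated ring carbon).

For the measured compounds named here, no measured pair of compounds shows what this change does on its own. Compound 1 also carries an acetoxy on the ring and stands at a limit, but it differs from compound 4 in other places too. Compound 3, at 8.6 ug/mL, is therefore the best guide. The expected step of a 1.1-fold lower number from compound 3 to compound 4 (0.03 log units; within the scatter) stays within the usual scatter, with no firm direction. For compound 4 the estimated value is 8 ug/mL, with an expected range from 3 ug/mL to 20 ug/mL.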

Compound 4, concentration for half-maximal effect: 6.3 ug/mL
For compound 4 the middle estimate is 1.3-fold (0.10 log units) above the measured one; the measured number falls inside the stated range.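

This pair is the first among the compounds shown to isolate one change: acetoxy in place of hydrogen on a saturated ring carbon, next to the ring atom that bears a large group. In this assay, the result is a 1.4-fold lower number from compound 3 to compound 4 (0.14 log units; within the scatter), so the two values cannot be told apart and the step has no firm direction. The position therefore carries an acetoxy while the compound still gives a true number in this cell assay, although this single pair says nothing about whether the group helps or harms, and it sets no pattern for other positions on the ring.

On these data alone, what a different group at this ring carbon would do stays open, whether a small one such as hydroxy or one with other chemistry such as an amine or a benzoyloxy ester. Compound 1 and compound 2 cannot settle this, as each stands at a limit and neither forms a one-place pair with compound 4, leaving the steps to them unreadable: the limit of > 20 ug/mL in this assay, at which 2 of the 4 values shown sit.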